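Hydroxymethyl on the sulfonamide chain of compound 1

This account rests on a few compounds, and the source may have more. Where it says the series, first, only, none or still open, it means among the compounds named here.

Among the measured compounds shown here, in a functional assay on Huh-7 cells (Homo sapiens) for antiproliferative activity, read by CCK-8 assay, with a stated time of 72 h (on this read-out lower numbers stand for stronger inhibition of growth and higher numbers for weaker inhibition of growth), compound 1 (`CC[C@@H]1C(=O)N(C)c2cnc(Nc3ccc(S(=O)(=O)NC)cc3)nc2N1C1CCCC1`) gives 99 nM and holds the lower of the two numbers so far. Compound 2 (`CCCCNC(=O)c1ccc2c(ccn2-c2ncc3c(n2)N(C2CCCC2)[C@H](CC)C(=O)N3C)c1`) gives 683 nM and sits beyond the scatter from compound 1, but the two differ in more than one place, so this gap isolates no single change. Compound 3 (`CC[C@@H]1C(=O)N(C)c2cnc(Nc3ccc(S(=O)(=O)NCCO)cc3)nc2N1C1CCCC1`) is compound 1 with one alteration (hydroxymethyl in place of hydrogen on a saturated chain carbon bound to a sulfonamide nitrogen), which reads as methylsulfamoyl to (2-hydroxyethyl)sulfamoyl. For the measured compounds named here, no measured pair covers this change, so any forecast is uncertain. In this assay a small move towards a higher number is expected, possibly none beyond the scatter. The estimated step is a 1.3-fold higher number from compound 1 to compound 3 (0.12 log units; within the scatter) and would leave growth inhibition close to the starting level. The expected value for compound 3 is 130 nM (estimated range 50 nM to 340 nM).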

Compound 3, concentration for 50% growth inhibition: 278 nM
The estimate for compound 3 lay 2.1-fold (0.33 log units) below the measured number; the measured number falls inside the stated range.
By their numbers in this assay, from the lowest: compound 1; then compound 3; then compound 2.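

In this assay, among the compounds shown here, the sulfonamide chain gives the first reading of a single change: hydroxymethyl in place of hydrogen on a saturated chain carbon bound to a sulfonamide nitrogen gives a 2.8-fold higher number from compound 1 to compound 3 (0.45 log units; beyond the scatter) as a modest loss of growth inhibition. This position therefore responds to the change from methylsulfamoyl to (2-hydroxyethyl)sulfamoyl, though this single pair shows only a modest cost. No measurement shown bears on the reason for this step.

The compounds shown leave open whether the added carbon or the hydroxyl accounts for the step, and an ethyl group on the sulfonamide nitrogen would help to separate the two. From the compounds shown here alone, how an amine, a carboxylic acid or a longer chain would read at this place also remains open.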